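Adding Ethyl to the Chain of Compound 2

The compounds below may be only part of what the source reports. "The series", "measured", "known", "first", "only" and "open" are said of these compounds alone.

In a functional assay on THP-1 cells (Homo sapiens) for inhibition, read by ELISA, with stated times of 2 h and 48 h (on this read-out lower numbers stand for stronger inhibition and higher numbers for weaker inhibition), compound 1 (`CCCCCCCCCCn1cc(/C=[N+](\[O-])c2ccccc2)nn1`) gives 9900 nM while compound 2 (`CCCCCCCCn1cc(/C=[N+](\[O-])Cc2ccccc2)nn1`) gives 13100 nM and these two numbers sit within the usual scatter of repeated measurements, so compound 2 stands level with compound 1 and neither can be ranked. Compound 3 (`CCCCCCCCCCn1cc(/C=[N+](\[O-])Cc2ccccc2)nn1`) is still unmeasured. It carries a single change from compound 2 (ethyl in place of hydrogen on a saturated chain carbon, eight bonds along the chain from an aromatic nitrogen), namely ethyl in place of hydrogen on a saturated chain carbon, eight bonds along the chain from an aromatic nitrogen. Among the measured compounds shown here, no measured pair shows this change alone. The chain of compound 3 also appears on compound 1, which gives 9900 nM on a different core. In this assay the expected effect is therefore modest. The estimated step of a 1.4-fold lower number from compound 2 to compound 3 (0.14 log units; within the scatter) points toward a lower number and stays within the scatter. The estimated value for compound 3 is 9500 nM (4000 nM to 20000 nM).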

Compound 3, half-maximal inhibitory concentration: 15600 nM
The estimate for compound 3 lay 1.6-fold (0.22 log units) below the measured number, within the range that was stated.
By their numbers in this assay, from the lowest: compounds 1, 2 and 3 (each within the scatter of the next).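

In this assay, among the compounds shown here, ethyl in place of hydrogen on a saturated chain carbon, eight bonds along the chain from an aromatic nitrogen, gives a 1.2-fold higher number from compound 2 to compound 3 (0.08 log units; within the scatter), the first direct reading of this change, and the two compounds stand level. For the compounds shown here, compound 3 also provides the first single-change comparison at the double-bonded nitrogen: benzyl in place of phenyl gives a 1.6-fold higher number from compound 1 to compound 3 (0.20 log units; within the scatter), so these two compounds cannot be ranked either. No measurement here bears on what lies behind these two results.

Still open, on these data alone, is whether an amine or a carboxylic acid on this chain carbon, or a much longer chain, would move the number beyond the scatter. Also open, as far as these compounds go, is how a compound with phenyl on the double-bonded nitrogen and the chain of compound 2 would compare.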